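Benzylcarbamoyl for methoxy on the shared core

The compounds below may be only part of what the source reports. "The series", "measured", "known", "first", "only" and "open" are said of these compounds alone.

compound 1 `COc1cccc(N2C(=O)N/C(=C\c3ccc(O)cc3)C2=O)c1` > 200000 nM
compound 2 `CCOC(=O)c1ccc(N2C(=O)N/C(=C\c3ccc(O)cc3)C2=O)cc1` > 200000 nM

In a functional assay on NCI-H292 cells (Homo sapiens) for antiproliferative activity (a lower number here means a stronger inhibitor, a higher number a weaker inhibitor), compound 1 gives > 200000 nM, which is a limit of the assay and not a number. Compound 2 gives > 200000 nM, likewise a limit. Compound 1 therefore stands at the limit of the series (the limit of > 200000 nM in this assay, at which 2 of the 2 values shown sit). Compound 3 `O=C(NCc1ccccc1)c1cccc(N2C(=O)N/C(=C\c3ccc(O)cc3)C2=O)c1` differs from compound 1 by benzylcarbamoyl in place of methoxy on an aromatic carbon. For the measured compounds named here, no measured step exists for comparison, and both known values are limits, so no step beyond the scatter is expected in this assay. Compound 3 is expected at 200000 nM (40000 nM to 1000000 nM). The estimated step is a number no higher from compound 1 to compound 3 (the limit leaves the size open), most likely again a limit.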

Compound 3, half-maximal inhibitory concentration: 23500 nM
The estimate for compound 3 lay 8.5-fold (0.93 log units) above the measured number, outside the stated range (below it).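

In this assay, benzylcarbamoyl in place of methoxy on an aromatic carbon, meta to a large group, gives an at least 8.5-fold lower number from compound 1 to compound 3 (0.92 log units; beyond the scatter). This position can therefore carry a change that brings the series from a limit to a measurable number. Only compound 3 gives such a number, and the other values shown are limits: the limit of > 200000 nM in this assay, at which 2 of the 3 values shown sit.

The compounds shown leave open whether the step comes from the amide hydrogen, the carbonyl or the added aromatic ring. A primary carboxamide, a carboxylic acid or a longer chain between the amide nitrogen and the ring at this position would help separate these parts.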